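Adding chloro to compound 2

This account rests on a few compounds, and the source may have more. Where it says the series, first, only, none or still open, it means among the compounds named here.

In a functional assay on Bel-7402 cells (Homo sapiens) for inhibition, read by MTT assay, with a stated time of 24 h, tested at 10 ug/mL (a higher number here means more inhibition of growth at the concentration tested, a lower number less inhibition of growth), compound 2 (`O=C(CCCCC1CCSS1)Nc1ccccn1`) gives 5.77% and compound 1 (`O=C(CCCCC1CCSS1)NO`) gives 11.8% so the two sit within the scatter of each other. Compound 3 (`O=C(CCCCC1CCSS1)Nc1ccc(Cl)cn1`) has chloro in place of hydrogen on an aromatic carbon with chloro in place of hydrogen on an aromatic carbon. Within the data shown here, the one measured step, a number 6 percentage points lower from compound 1 to compound 2 (within the scatter) for pyridin-2-yl in place of hydroxy on an amide-type nitrogen, involves no chloro group and offers only a weak guide. The expected change is a number 3.2 percentage points higher from compound 2 to compound 3 (within the scatter) with nothing beyond the scatter foreseen. Compound 3 is expected to give 9% (estimated range 1% to 20%).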

Compound 3, percent growth inhibition at one concentration: 16.1%
Compound 3: the middle estimate sits 7.1 percentage points below what was measured; the measured number falls inside the stated range.
By their numbers in this assay, from the lowest: compounds 2, 1 and 3 (each within the scatter of the next, the first and the last beyond it).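

Chloro on the aromatic carbon two atoms from the ring nitrogen, para to a large group, gives a number 10.3 percentage points higher from compound 2 to compound 3 (beyond the scatter) and is the first step here to clear the usual scatter, if only modestly. Among these compounds, the earlier step, a number 6 percentage points lower from compound 1 to compound 2 (within the scatter), stayed within it, so this ring position is the first place where one small change clearly moves growth inhibition. No evidence here explains the gain. From the compounds shown here alone, whether fluoro or methoxy on the same carbon would do the same remains open, as does the effect of chloro elsewhere on the ring.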